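Benzyl on the piperazine nitrogen in MCF7 cytotoxicity

The source may report more compounds than this note shows. Statements on the series, on what has been measured and on what is new or still open speak of the compounds shown alone.

Compound 2 `CN(C)/C=C/N1CCN(CC(=O)Nc2ccc(-c3nc(-c4ccccc4)c(-c4ccccc4)n3C)cc2)CC1` gives 19.4% in a functional assay on MCF7 cells (Homo sapiens) for cytotoxicity, read by MTT assay, with a stated time of 24 h, tested at 16 ug/mL (a higher number here means a stronger effect of the compound at the concentration tested, a lower number a weaker effect), the lowest of the two numbers in hand; compound 1 `CN1CCN(CC(=O)Nc2ccc(-c3nc(-c4ccccc4)c(-c4ccccc4)n3C)cc2)CC1` gives 30.1%. For the measured compounds named here, the one measured step, a number 10.7 percentage points lower from compound 1 to compound 2 (beyond the scatter), is the only guide for the change to compound 3 `Cn1c(-c2ccc(NC(=O)CN3CCN(Cc4ccccc4)CC3)cc2)nc(-c2ccccc2)c1-c1ccccc1`: benzyl in place of 2-(dimethylamino)ethenyl on an amine nitrogen in a ring. That step does not involve benzyl, so its bearing is indirect. Since compound 2 sits below compound 1 by a number 10.7 percentage points lower from compound 1 to compound 2 (beyond the scatter), a return toward that range is expected, giving an estimated step of a number 8.6 percentage points higher from compound 2 to compound 3 (within the scatter). Compound 3 is therefore expected to give 28%, within 12% to 45%.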

Compound 3, a percentage reported as activity, at one concentration (the size of the read-out at that concentration, not a potency): 28.3%
Beside the measured number, compound 3's estimate is 0.3 percentage points below it; low and high end bracket the measured number.
By their numbers in this assay, from the lowest: compounds 2, 3 and 1 (each within the scatter of the next, the first and the last beyond it).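

In this assay, the position on an amine nitrogen in a ring accepts benzyl, with its six-membered aromatic ring of carbon only, and a number 1.8 percentage points lower from compound 1 to compound 3 (within the scatter) leaves it unseparated from the methyl of compound 1. The change from 2-(dimethylamino)ethenyl, a number 8.9 percentage points higher from compound 2 to compound 3 (within the scatter), also stays inside the scatter, so compound 3 cannot be told apart from either neighbour. Nothing on hand speaks to the reason for these numbers. From the compounds shown here alone, whether a benzyl bearing fluorine or methoxy on its ring, or an acetyl or a free hydrogen on that nitrogen, would read apart from these three remains open.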